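Chloro at the aryl ring of the ethyl ester series

A few compounds are considered here, and "the series" means these few. Any claim that something is new, unique, unknown or untested is made for them only; others in the source may bear on it.

Going by the values given here, compound 2 `CCOC(=O)c1sc(-c2ccccc2)nc1O` sits lowest among the numbers so far in an assay on HEK293 cells for inhibition of transient receptor potential cation channel subfamily M member 8 (Homo sapiens), read by FLIPR, with stated times of 5 min and 3 min (on this read-out lower numbers stand for stronger inhibition and higher numbers for weaker inhibition), where compound 2 gives 32 nM. The nearest neighbour is compound 1 `CCOC(=O)c1sc(-c2ccc(F)cc2)nc1O`, which in this assay gives 80 nM; the step of a 2.5-fold lower number from compound 1 to compound 2 (0.40 log units; beyond the scatter) is modest but beyond the scatter. Compound 3 `O=C(O)c1sc(-c2ccccc2)nc1O` reports only a limit in this assay, > 100000 nM, not a number. The step of an at least 3100-fold higher number from compound 2 to compound 3 (3.49 log units; beyond the scatter) is large, and it is this free acid that sits at the limit described as the limit of > 100000 nM in this assay, at which 1 of the 3 values shown sits.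

Compound 4 `CCOC(=O)c1sc(-c2cccc(Cl)c2)nc1O` differs from compound 2 only on the phenyl ring: chloro in place of hydrogen on an aromatic carbon. Among the compounds with values here, no measured step changes a ring hydrogen for chloro, and the one ring substitution on record, fluoro to hydrogen, moved the number by the modest amount seen from compound 1 to compound 2. The ester that drives the large step to compound 3 is kept intact in compound 4. The expectation is therefore a step within the scatter or a slight rise in this assay, expressed as a 1.4-fold higher number from compound 2 to compound 4 (0.15 log units; within the scatter). Compound 4 is estimated at 45 nM in this assay, with a range from 14 nM to 140 nM.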

Compound 4, half-maximal inhibitory concentration: 1300 nM
Beside the measured number, compound 4's estimate is 29-fold (1.46 log units) below it; measured number outside the range, above it.
By their numbers in this assay, from the lowest: compound 2; then compound 1; then compound 4. At a limit, above all of these: compound 3.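

Chloro in place of hydrogen on an aromatic carbon, meta to a large group, gives a 41-fold higher number from compound 2 to compound 4 (1.61 log units; beyond the scatter) in this assay and so shows that this place on the phenyl ring does not merely tolerate change. Going by these compounds alone, until now the only large step lay at the ester, where hydrogen in place of ethyl gives an at least 3100-fold higher number from compound 2 to compound 3 (3.49 log units; beyond the scatter) in this assay, but here the ethyl ester stays intact and a single atom on the ring is enough for a large rise. Within the data shown here, the one earlier ring step, a 2.5-fold lower number from compound 1 to compound 2 (0.40 log units; beyond the scatter) in this assay, is modest, so ring changes now span modest to large steps, although compound 1 and compound 4 differ in more than one place and cannot be compared directly.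

Going by these compounds, whether a methoxy group or an amine at this same place behaves as chloro does remains open, as does the effect of chloro elsewhere on the phenyl ring or of a longer chain on the ester oxygen. Nothing measured in this series explains why chloro moves the number this far.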